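The source may report more compounds than this note shows. Statements on the series, on what has been measured and on what is new or still open speak of the compounds shown alone.

Series notes. Compound 1 `O=C(NCc1ccc(S(=O)(=O)N2CCCCC2)cc1)c1ccn2cncc2c1` reports only a limit in a functional assay on A2780 cells (Homo sapiens) for inhibition, read by sulforhodamine B assay, with a stated time of 72 h (on this read-out higher numbers stand for weaker inhibition and lower numbers for stronger inhibition), namely > 10000 nM (the limit of > 10000 nM in this assay, at which 1 of the 3 values shown sits). Compound 2 `O=C(NCc1ccc(S(=O)(=O)N2CCCCC2)cc1)c1cnc2nccn2c1` gives 130 nM in this assay, and compound 3 `O=C(NCc1ccc(S(=O)(=O)N2CCCCC2)cc1)c1cc2cnccc2o1` gives 1500 nM; compound 3 thus carries the highest of the two finite numbers, its nearest neighbour being reached by a 12-fold higher number from compound 2 to compound 3 (1.06 log units; beyond the scatter). Compound 4 `O=C(NCc1ccc(S(=O)(=O)N2CCCCC2)cc1)c1cc2cccnc2s1` is not yet measured. The change is a group of 9 heavy atoms (7 carbon, 1 nitrogen, 1 sulfur; one five-membered aromatic ring with 1 hetero atom, one six-membered aromatic ring with 1 hetero atom) in place of a group of 9 heavy atoms (7 carbon, 1 nitrogen, 1 oxygen; one five-membered aromatic ring with 1 hetero atom, one six-membered aromatic ring with 1 hetero atom), on a carbonyl carbon. Every measured step exchanges a whole bicyclic group on the carbonyl carbon, as in an at least 6.6-fold lower number from compound 1 to compound 3 (0.82 log units; beyond the scatter) and an at least 76-fold lower number from compound 1 to compound 2 (1.88 log units; beyond the scatter), and none exchanges a single ring atom; the present change keeps ring sizes and the counted donors and acceptors unchanged. A step within the scatter is therefore expected, a 1.5-fold lower number from compound 3 to compound 4 (0.18 log units; within the scatter). Compound 4 is estimated at 1000 nM, range 300 nM to 4000 nM.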

Compound 4, half-maximal inhibitory concentration: > 10000 nM
Compound 4 was reported as a limit (the forecaster's own chance of this, stated with the estimate: 5%); at least 10-fold (1.00 log units) between middle value and limit.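

The change on the carbonyl carbon keeps ring sizes and the counted donors and acceptors, yet it gives an at least 6.6-fold higher number from compound 3 to compound 4 (0.82 log units; beyond the scatter) in this assay, so matching these counts does not preserve the read-out in this series. The sulfur-containing group also gives an at least 76-fold higher number from compound 2 to compound 4 (1.88 log units; beyond the scatter) and thus remains well short of the best group shown. Compound 4 is reported only as a limit, and the steps that the two limits leave unreadable cannot be read: the limit of > 10000 nM in this assay, at which 2 of the 4 values shown sit.

From the compounds shown here alone, it remains open whether the sulfur or the place of the ring nitrogen carries the step, and what an amine on this bicyclic group would give in this assay.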